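Cathepsin S binders: a cycloheptyl for cyclohexyl exchange

The compounds below may be only part of what the source reports. "The series", "measured", "known", "first", "only" and "open" are said of these compounds alone.

Compounds with a reported value:
- compound 2, `N#C[C@@]1(NC(=O)[C@@H](CC(=O)N2CCOCC2)CC2CCCCC2)CCN(C2CCCCC2)C1`: 17.8 nM

Compound 1, `N#C[C@@]1(NC(=O)[C@@H](CC(=O)N2CCOCC2)CC2CCCCC2)CCN(C2CCCC2)C1`, belongs to the same series, but for compound 1 the result is reported as "not determined" (no result reported).

In an assay on isolated protein for inhibition of cathepsin S (Homo sapiens) (a lower number here means tighter binding, a higher number weaker binding), compound 2 gives 17.8 nM. Among the compounds with values here, this is the only number available in this assay, so compound 2 stands alone as the reference point; compound 1 adds no figure that could be compared with it, and no step between measured compounds can be drawn.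

Compound 3, `N#C[C@@]1(NC(=O)[C@@H](CC(=O)N2CCOCC2)CC2CCCCC2)CCN(C2CCCCCC2)C1`, has not yet been measured. It differs from compound 2 in a single place: cycloheptyl in place of cyclohexyl on an amine nitrogen in a ring. Nothing in the available data shows how this assay responds to such an exchange on the amine nitrogen in the ring, so the expectation rests on compound 2 alone and on the modest nature of the change.

The step from compound 2 to compound 3 is expected to be small, a 1.2-fold higher number from compound 2 to compound 3 (0.09 log units; within the scatter), with no clear direction beyond the usual scatter. Compound 3 is therefore estimated at 22 nM, within a range of 7 nM to 70 nM, leaving the measurement to settle the matter.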

Compound 3, dissociation constant: 11 nM
Compound 3: the middle estimate sits 2.0-fold (0.30 log units) above what was measured, and the stated range covers the measured number.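

Within the data shown here, this is the first step that can be read at this position, on an amine nitrogen in a ring: in this assay, cycloheptyl in place of cyclohexyl gives a 1.6-fold lower number from compound 2 to compound 3 (0.21 log units; within the scatter) and so leaves compound 2 and compound 3 indistinguishable in this read-out. At this place, then, a seven-membered non-aromatic ring of carbon only and a six-membered one give values that this assay does not separate, although that finding rests on a single pair. No independent measurement bears on why the two values stand as they do.

Among these compounds, compound 1, with cyclopentyl on the same nitrogen, is reported as "not determined" (no result reported) and adds no second step, so the response across ring sizes remains unread. Going by these compounds, it also remains open whether an open-chain isopropyl, a benzyl or a tetrahydropyranyl group on this nitrogen would move the number beyond the scatter, and whether the cycloheptyl for cyclohexyl exchange would read the same with other groups elsewhere on the shared core.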